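The compounds below may be only part of what the source reports. "The series", "measured", "known", "first", "only" and "open" are said of these compounds alone.

Compound 1 `Oc1ccccc1-c1cc(-c2ccccc2F)cc(-c2ccccc2O)n1`: in a functional assay on DU-145 cells (Homo sapiens) for inhibition (on this read-out lower numbers stand for stronger inhibition and higher numbers for weaker inhibition), compound 1 gives > 50000 nM, which is a limit of the assay and not a number.
Compound 2 `Oc1cccc(-c2cc(-c3ccccc3F)cc(-c3ccccc3O)n2)c1`: in this assay compound 2 gives 35600 nM.
Compound 3 `Oc1ccc(-c2cc(-c3ccccc3F)cc(-c3cccc(O)c3)n2)cc1`: in this assay compound 3 gives 3160 nM.

Among the two numbers shown, compound 2 has the highest, and its nearest neighbour is compound 3, reached by an 11-fold lower number from compound 2 to compound 3 (1.05 log units; beyond the scatter). The remaining value is the limit described by the limit of > 50000 nM in this assay, at which 1 of the 3 values shown sits. The step from compound 1 to compound 2, an at least 1.4-fold lower number from compound 1 to compound 2 (0.14 log units; that floor lies within the scatter), has a floor that lies within the scatter.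

Compound 4 `Oc1cccc(-c2cc(-c3cccc(C(F)(F)F)c3)cc(-c3ccccc3O)n2)c1` differs from compound 2 in one place: 3-(trifluoromethyl)phenyl in place of 2-fluorophenyl on an aromatic carbon. Within the data shown here, both measured steps concern the hydroxyphenyl groups on the shared core, and neither touches the group that is exchanged here, so no measured step bears directly on this change. The two steps show that moving a hydroxy group can shift the number a great deal, but that gives no direction for a trifluoromethyl group entering in place of a fluorine.

The expected step in this assay from compound 2 to compound 4 is therefore small or none beyond the scatter, with a wide range: a 1.2-fold lower number from compound 2 to compound 4 (0.07 log units; within the scatter). Compound 4 is expected to give about 30000 nM, with a range from 8000 nM to 100000 nM.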

Compound 4, half-maximal inhibitory concentration: 13000 nM
The estimate for compound 4 lay 2.3-fold (0.36 log units) above the measured number, within the range that was stated.
By their numbers in this assay, from the lowest: compound 3; then compound 4; then compound 2. At a limit, above all of these: compound 1.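

In this assay, the change at the position opposite the ring nitrogen gives a 2.7-fold lower number from compound 2 to compound 4 (0.44 log units; beyond the scatter), a modest step. Among these compounds, the earlier steps concerned only the hydroxyphenyl groups, so this is the first sign that the number also responds to the group at this position, and that a group with more heavy atoms can stand here without the number rising. Among the compounds shown here, nothing measured here accounts for this step, and the only other information available concerns a limit of the assay.

The change also alters two things at once, the fluorine-bearing group and its place on the phenyl ring, so the compounds shown cannot separate these two contributions, and a 3-fluorophenyl or 2-(trifluoromethyl)phenyl group at this position would be needed to tell them apart. From the compounds shown here alone, it also remains open how an amine or a carboxylic acid on this phenyl ring would read, and whether the same exchange would lower the number on the hydroxyphenyl arrangement of compound 3.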